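The source may hold more compounds than are shown below. What is called first, only, known or untested is meant among the compounds shown, and "the series" means these compounds.

Measured in an ADME assay on L02 cells (Homo sapiens) for cytotoxicity, read by MTT assay; on this read-out higher numbers stand for weaker inhibition and lower numbers for stronger inhibition:
compound 1 `COc1cc(/C=C/c2nc(NC3CC3)c3sccc3n2)cc(OC)c1OC` gives 2360000 nM
compound 2 `COc1ccc(Nc2nc(/C=C/c3cc(OC)c(OC)c(OC)c3)nc3ccsc23)cc1` gives 279000 nM
compound 3 `COc1cc(/C=C/c2nc(NCc3ccc(C)cc3)c3sccc3n2)cc(OC)c1OC` gives 2930000 nM

Compound 3 has the highest of the three numbers in this assay. Its nearest neighbour is compound 1: a 1.2-fold higher number from compound 1 to compound 3 (0.09 log units; within the scatter). Its furthest is compound 2: an 11-fold higher number from compound 2 to compound 3 (1.02 log units; beyond the scatter). The remaining measured step, an 8.5-fold lower number from compound 1 to compound 2 (0.93 log units; beyond the scatter), likewise exchanges the whole group on the ring nitrogen.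

Compound 4 `COc1cc(/C=C/c2nc(NCc3ccc(Cl)cc3)c3sccc3n2)cc(OC)c1OC` differs from compound 3 only in chloro in place of methyl on an aromatic carbon. Among the compounds with values here, none of the measured steps bears directly on this: each of them swaps the entire substituent on the nitrogen rather than a single group on the 4-methylbenzyl ring, and the only one that retains a closely related group, a 1.2-fold higher number from compound 1 to compound 3 (0.09 log units; within the scatter), stays within the scatter. There is no measured change of the methyl-to-chloro kind in this set. The expectation is therefore no step beyond the scatter: a 1.2-fold lower number from compound 3 to compound 4 (0.07 log units; within the scatter). Compound 4 is expected to give 2500000 nM in this assay, with a range from 1200000 nM to 5500000 nM.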

Compound 4, half-maximal inhibitory concentration: 4320000 nM
Compound 4: the middle estimate sits 1.7-fold (0.24 log units) below what was measured, and the stated range covers the measured number.
By their numbers in this assay, from the lowest: compound 2; then compounds 1, 3 and 4 (each within the scatter of the next).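

In this assay, within the data shown here, chloro in place of methyl on an aromatic carbon, para to a large group, is the first change within the 4-methylbenzyl group rather than of the whole substituent on the nitrogen, and it stays within the scatter (a 1.5-fold higher number from compound 3 to compound 4 (0.17 log units; within the scatter)). The 4-chlorobenzyl group also stays within the scatter against cyclopropyl (a 1.8-fold higher number from compound 1 to compound 4 (0.26 log units; within the scatter)) but stands well apart from 4-methoxyphenyl (a 15-fold higher number from compound 2 to compound 4 (1.19 log units; beyond the scatter)), so compound 2 remains alone at the low end of the series. Nothing measured here accounts for these numbers.

As far as these compounds go, whether a methoxy group, an amine or a carboxylic acid at this ring position would give a step beyond the scatter remains open. Also open, from the compounds shown here alone, is whether the separate standing of compound 2 goes with its methoxy group or with the phenyl ring sitting directly on the nitrogen.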